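The compounds below may be only part of what the source reports. "The series", "measured", "known", "first", "only" and "open" are said of these compounds alone.

Only compound 1 `O=C1C=CC[C@@H]([C@H](O)[C@H](O[C@@H](c2ccccc2)[C@@H](O)[C@@H]2CC=CC(=O)O2)c2ccccc2)O1` and compound 2 `O=C1C=CC[C@@H]([C@H](O)[C@@H](O[C@H]([C@@H]2CC=CC(=O)O2)[C@@H](O)c2ccccc2)c2ccccc2)O1` have been measured so far. In a functional assay on Calu-1 cells (Homo sapiens) for cytotoxicity, read by luminescence and CellTiter-Glo, with a stated time of 72 h (on this read-out higher numbers stand for weaker inhibition and lower numbers for stronger inhibition), compound 1 gives 5400 nM and compound 2 gives 7500 nM, two values within the usual scatter of each other. Compound 3 `CC(=O)O[C@@H]([C@@H]1CC=CC(=O)O1)[C@H](O[C@@H](c1ccccc1)[C@@H](O)[C@@H]1CC=CC(=O)O1)c1ccccc1` keeps the core of compound 1 and differs in one place, hydroxy to acetoxy: acetyl in place of hydrogen on an oxygen on a saturated carbon. Among the compounds with values here, no measured step shows what such a change does in this assay, so no shift beyond the scatter is expected. The expected 1.2-fold lower number from compound 1 to compound 3 (0.08 log units; within the scatter) is small. Compound 3 is estimated at 4500 nM, with an expected range from 1500 nM to 12000 nM.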

Compound 3, half-maximal inhibitory concentration: 2200 nM
Compound 3: the middle estimate sits 2.0-fold (0.31 log units) above what was measured; the range from low to high includes it.
By their numbers in this assay, from the lowest: compound 3; then compounds 1 and 2 (each within the scatter of the next).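

In this assay the change from hydroxy to acetoxy gives a 2.5-fold lower number from compound 1 to compound 3 (0.39 log units; beyond the scatter) and so goes beyond the scatter, a modest gain in inhibition. At this oxygen on a saturated carbon, the hydrogen of the hydroxy group is therefore not needed for activity on these cells, and an acetyl group is accepted in its place. Nothing at hand explains the shift.

Still open, on these data alone, is whether a longer acyl chain such as butyryl would lower the number further. A methyl ether or a carbamate on the same oxygen is equally untested in the compounds shown here.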